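Fluorine on the Sulfonyl Ring, Carried to a Second Core

This account rests on a few compounds, and the source may have more. Where it says the series, first, only, none or still open, it means among the compounds named here.

Measured compounds:
compound 1, `Cc1cc(N2CCNCC2)c2c(c1)N(S(=O)(=O)c1ccccc1)CCO2`, 2.51 nM
compound 2, `Cc1cc(N2CCNCC2)c2c(c1)N(S(=O)(=O)c1ccccc1F)CCO2`, 0.398 nM
compound 3, `CC1(C)CN(S(=O)(=O)c2ccccc2)c2cc(F)cc(C3CCNCC3)c2O1`, 3.98 nM

In an assay on HEK293 cells for displacement of a labelled ligand from 5-hydroxytryptamine receptor 6 (Homo sapiens) (on this read-out lower numbers stand for stronger inhibition and higher numbers for weaker inhibition), compound 1 gives 2.51 nM. Compound 2 differs from it by fluoro in place of hydrogen on an aromatic carbon, and this change brought a 6.3-fold lower number from compound 1 to compound 2 (0.80 log units; beyond the scatter). Compound 3 rests on a different core, and the difference between the two cores is not broken down here; in this assay compound 3 gives 3.98 nM, which sits within the usual scatter of the value of compound 1.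

Compound 4, `CC1(C)CN(S(=O)(=O)c2cccc(F)c2)c2cc(F)cc(C3CCNCC3)c2O1`, is not yet measured. It differs from compound 3 by fluoro in place of hydrogen on an aromatic carbon. For the measured compounds named here, this is the same kind of change as the one from compound 1 to compound 2, but not the same: in compound 2 the fluoro stands ortho to a large group, in compound 4 it stands meta to a large group. From the compounds shown here alone, because the step of a 6.3-fold lower number from compound 1 to compound 2 (0.80 log units; beyond the scatter) was seen only for the ortho placement, and the meta placement is untested here, a smaller step is expected for compound 4 in this assay, namely a 2.5-fold lower number from compound 3 to compound 4 (0.40 log units; beyond the scatter). Compound 4 is therefore estimated at 1.6 nM, with a range from 0.5 nM to 5 nM.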

Compound 4, inhibition constant: 5.01 nM
Beside the measured number, compound 4's estimate is 3.1-fold (0.50 log units) below it; the whole stated range lies below it.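

On the core of compound 3, going from phenyl to 3-fluorophenyl gave a 1.3-fold higher number from compound 3 to compound 4 (0.10 log units; within the scatter) in this assay, so no real change in binding can be claimed for this step. The same kind of change therefore did not bring the same result on the two cores: the same change on two cores in this assay, a 6.3-fold lower number (0.80 log units; beyond the scatter) from compound 1 to compound 2 and a 1.3-fold higher number (0.10 log units; within the scatter) from compound 3 to compound 4, 7.9-fold (0.90 log units) apart, beyond the scatter of two such steps The data do not show why, since two things differ at once: the core, and the place of the fluoro, which in compound 4 stands meta to a large group and in compound 2 stands elsewhere on the ring.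

From the compounds shown here alone, it remains open whether the fluoro placed as in compound 2 would bring a similar step on the core of compound 3, and whether the placement in compound 4 would leave the value on the core of compound 1 as flat as it did here. Going by these compounds, how other groups on this same ring, such as chloro, methoxy or a nitrile, would read out on either core also remains open.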